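The source may hold more compounds than are shown below. What is called first, only, known or untested is meant among the compounds shown, and "the series" means these compounds.

Compound 1 `N#Cc1cnc(NCc2ccccc2C(F)(F)F)cc1N[C@H]1CC[C@@H](O)CC1`: 0%
Compound 2 `N#Cc1cnc(NCc2cncnc2C(F)(F)F)cc1N[C@H]1CC[C@@H](O)CC1`: 76%
Compound 3 `CC(C)(F)c1ncncc1CNc1cc(N[C@H]2CC[C@@H](O)CC2)c(C#N)cn1`: 89%

In an ADME assay on S9 fraction from liver (Homo sapiens) for metabolic stability, with a stated time of 1 h (a higher number here means that more of the compound is left, a lower number that less of the compound is left), compound 3 has the highest number of the three at 89%, above compound 2 and far above compound 1. Compound 4 `COc1ncncc1CNc1cc(N[C@H]2CC[C@@H](O)CC2)c(C#N)cn1` has not yet been measured. It carries methoxy in place of 1-fluoro-1-methylethyl on an aromatic carbon.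

For the measured compounds named here, one measured step bears on this change, as it concerns the same aromatic carbon: a number 13 percentage points higher from compound 2 to compound 3 (beyond the scatter). That step was modest and swapped trifluoromethyl for 1-fluoro-1-methylethyl. Going by the values given here, no compound with methoxy has been measured, so the direction rests on little. Compound 3 already stands near the top of the scale at 89%, which leaves little room to rise, so a modest fall of about the size of the measured step is expected in this assay. The expected change is a number 13 percentage points lower from compound 3 to compound 4 (beyond the scatter). For compound 4 the estimated value is 76%, with an expected range from 55% to 93%.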

Compound 4, percent of the compound remaining: 88%
Estimate against measurement, compound 4: 12 percentage points below; the range from low to high includes it.
By their numbers in this assay, from the lowest: compound 1; then compound 2; then compounds 4 and 3 (each within the scatter of the next).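

In this assay, methoxy in place of 1-fluoro-1-methylethyl gives a number 1 percentage points lower from compound 3 to compound 4 (within the scatter), so at this aromatic carbon, next to the ring nitrogen, the smaller methoxy group, with its hydrogen-bond acceptor, reads level with the larger group. Methoxy also gives a number 12 percentage points higher from compound 2 to compound 4 (beyond the scatter), which makes it a second replacement for trifluoromethyl here that leaves a number beyond the scatter from that of compound 2, alongside a number 13 percentage points higher from compound 2 to compound 3 (beyond the scatter). No measurement shown accounts for these readings.

The compounds shown leave open how an amine or a longer chain such as ethoxy would read at this carbon in this assay. They also leave open whether methoxy would lift the number on the core of compound 1, which stands at 0%.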